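The source may hold more compounds than are shown below. What is called first, only, known or untested is meant among the compounds shown, and "the series" means these compounds.

In a functional assay on P388 cells (Mus musculus) for cytotoxicity (on this read-out lower numbers stand for stronger inhibition and higher numbers for weaker inhibition), compound 3 `C=CCN1C(=O)[C@@H](C)NC(=O)[C@@H]2Cc3ccc(OC)c(c3)Oc3ccc(cc3)C[C@@H](C(=O)N2C)N(C)C(=O)[C@H](C)NC(=O)[C@H](Cc2ccc(OC)cc2)N(C)C(=O)[C@@H]1C` gives 18.6 nM and lies within the scatter of compound 2 `CCC[C@@H]1NC(=O)[C@@H](C)NC(=O)[C@@H]2Cc3ccc(OC)c(c3)Oc3ccc(cc3)C[C@@H](C(=O)N2C)N(C)C(=O)[C@H](C)NC(=O)[C@H](Cc2ccc(OC)cc2)N(C)C1=O` at 13.8 nM in this small set. Compound 1 `COc1ccc(C[C@H]2C(=O)N[C@@H](C)C(=O)N(C)[C@H]3Cc4ccc(cc4)Oc4cc(ccc4OC)C[C@@H](C(=O)N[C@H](C)C(=O)N[C@@H](CS)C(=O)N2C)N(C)C3=O)cc1` gives 363 nM on the same read-out, a clearly higher number than either of them.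

The next analogue, compound 4 `COc1ccc(C[C@H]2C(=O)N[C@@H](C)C(=O)N(C)[C@H]3Cc4ccc(cc4)Oc4cc(ccc4OC)C[C@@H](C(=O)N[C@H](C)C(=O)N(C/C=C/c4ccccc4)[C@@H](C)C(=O)N2C)N(C)C3=O)cc1`, differs from compound 3 at one place: 2-phenylethenyl in place of vinyl on a saturated chain carbon bound to an amide-type nitrogen in a ring.

Among the compounds with values here, the only measured step is large: a 26-fold lower number from compound 1 to compound 2 (1.42 log units; beyond the scatter) (ethyl in place of sulfanyl on a saturated chain carbon bound to a saturated ring carbon). It involves other groups at another place, so it bears on this change only indirectly. It shows that a single substituent swap moved the number far between these two compounds. Within the data shown here, no measured compound tests the 2-phenylethenyl group, so the direction rests on judgement alone.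

A moderate rise in the number in this assay is expected, smaller than the step measured for the sulfanyl swap. The expected move is a 2.4-fold higher number from compound 3 to compound 4 (0.38 log units; beyond the scatter) as an estimate. For compound 4 the estimated value is 45 nM with an expected range from 12 nM to 200 nM on this read-out.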

Compound 4, half-maximal inhibitory concentration: 10.7 nM
Estimate against measurement, compound 4: 4.2-fold (0.62 log units) above; the whole stated range lies above it.
By their numbers in this assay, from the lowest: compounds 4, 2 and 3 (each within the scatter of the next); then compound 1.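

In this assay, 2-phenylethenyl in place of vinyl on a saturated chain carbon bound to an amide-type nitrogen in a ring gives a 1.7-fold lower number from compound 3 to compound 4 (0.24 log units; within the scatter), so the allyl to 3-phenylprop-2-en-1-yl change leaves the number within the scatter. This place in the shared core therefore accepts a substituent of 8 heavy atoms with one six-membered aromatic ring in place of one of 2 heavy atoms, with no shift that can be told from the scatter. The earlier compounds shown here could not show this, as none of them carries an aromatic ring on this chain, and the large step from the sulfanyl swap concerned another place. No measurement on hand accounts for this outcome.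

This is a single step at this place in a single assay, so it sets no limit on what the position accepts. Still open, on these data alone, is whether a 3-phenylpropyl chain, without the double bond, or an amine or a carboxylic acid at the end of the same chain would keep the number in the range of compound 3 and compound 4.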